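The compounds below may be only part of what the source reports. "The series", "measured", "known", "first", "only" and "open" are said of these compounds alone.

Measured compounds:
Compound 1, `COc1ccc(Nc2cc(C)oc(=O)c2)cc1`; in a functional assay on KB cells (Homo sapiens) for cytotoxicity, read by MTT assay, with a stated time of 72 h (on this read-out higher numbers stand for an effect only at larger amounts of compound and lower numbers for an effect already at smaller amounts), compound 1 gives only a limit, > 30 uM.
Compound 2, `COc1ccc(Nc2cc(C3CCCCC3)oc(=O)c2)cc1`; in this assay compound 2 gives 8.32 uM.
Compound 3, `CCCCCc1cc(Nc2ccc(OC)cc2)cc(=O)o1`; in this assay compound 3 gives 10.1 uM.

Compound 3 holds the highest of the two numbers in this assay, and its nearest neighbour is compound 2 with a 1.2-fold higher number from compound 2 to compound 3 (0.08 log units; within the scatter), so the two cannot be told apart. Compound 1 sits at the limit of > 30 uM in this assay, at which 1 of the 3 values shown sits.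

The step to compound 4, `COc1ccc(Nc2cc(/C=C/c3ccccc3)oc(=O)c2)cc1`, is 2-phenylethenyl in place of pentyl on an aromatic carbon. Two measured steps alter the group on the same aromatic carbon: an at least 3.6-fold lower number from compound 1 to compound 2 (0.55 log units; beyond the scatter) and an at least 2.9-fold lower number from compound 1 to compound 3 (0.47 log units; beyond the scatter), both at least modest lowerings when the small group of compound 1 is replaced by a larger one. Between the two larger groups, a 1.2-fold higher number from compound 2 to compound 3 (0.08 log units; within the scatter) lies within the scatter, so the lowering does not plainly grow further with size. The 2-phenylethenyl group is again larger than pentyl, and compound 4 is therefore expected to stay near compound 3 or to move only slightly toward lower numbers in this assay, with a 1.7-fold lower number from compound 3 to compound 4 (0.23 log units; within the scatter) estimated to fall within the scatter. Compound 4 is estimated at 6 uM, with a range from 2 uM to 20 uM.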

Compound 4, concentration for half-maximal effect: 0.15 uM
The estimate for compound 4 lay 40-fold (1.60 log units) above the measured number; measured number below the stated range.
By their numbers in this assay, from the lowest: compound 4; then compounds 2 and 3 (each within the scatter of the next). At a limit, above all of these: compound 1.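

In this assay, the position next to the ring oxygen proves far more responsive than compounds 1 to 3 suggested: 2-phenylethenyl gives a 67-fold lower number from compound 3 to compound 4 (1.83 log units; beyond the scatter) and a 55-fold lower number from compound 2 to compound 4 (1.74 log units; beyond the scatter), both large steps. The two earlier larger groups, pentyl and cyclohexyl, could not be told apart, with a 1.2-fold higher number from compound 2 to compound 3 (0.08 log units; within the scatter), so the flat picture among them does not extend to 2-phenylethenyl, the only group shown here that brings an aromatic ring and a double bond outside aromatic rings. Against the methyl group the change reads an at least 200-fold lower number from compound 1 to compound 4 (2.30 log units; beyond the scatter), and this size is only a bound, as the starting value is a limit: the limit of > 30 uM in this assay, at which 1 of the 4 values shown sits.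

Still open, as far as these compounds go, is whether the double bond, the aromatic ring or their combination carries the step, a question that a 2-phenylethyl or a directly attached phenyl group at this carbon would address. Also open, from the compounds shown here alone, is how far the low number in this assay survives a methoxy group, a hydroxyl group or an amine on the ring of the 2-phenylethenyl group.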